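Trimming a methoxy group to hydroxy

A few compounds are considered here, and "the series" means these few. Any claim that something is new, unique, unknown or untested is made for them only; others in the source may bear on it.

Compound 1 `Cc1cc(C)c(S(N)(=O)=O)c(C)c1NC(=O)c1sccc1S(=O)(=O)Nc1onc(C)c1Cl`: 30000 ug/mL
Compound 2 `COc1c(C)cc(C)c(NC(=O)c2sccc2S(=O)(=O)Nc2onc(C)c2Cl)c1C`: < 10000 ug/mL (a limit)

In a physicochemical assay for solubility, in phosphate buffer, at pH 7.4 (a higher number here means a more soluble compound, a lower number a less soluble compound), compound 2 gives < 10000 ug/mL, which is a limit of the assay and not a number. Compound 3 `Cc1cc(C)c(NC(=O)c2sccc2S(=O)(=O)Nc2onc(C)c2Cl)c(C)c1O` differs from compound 2 in one place: hydrogen in place of methyl on an oxygen on an aromatic ring, so methoxy becomes hydroxy. For the measured compounds named here, only one measured step bears on this, and only loosely: an at least 3.0-fold lower number from compound 1 to compound 2 (0.47 log units; beyond the scatter), where methoxy took the place of sulfamoyl. The new swap is smaller than that one, so a step of that size is not expected in this assay, and no step beyond the scatter is firmly expected in either direction. The expected change is a step that the limit leaves unreadable from compound 2 to compound 3. For compound 3 the estimated value is 8000 ug/mL, with an expected range from 2500 ug/mL to 25000 ug/mL.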

Compound 3, solubility: 83000 ug/mL
Estimate against measurement, compound 3: 10-fold (1.02 log units) below; the measured number lies above the stated range.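

In this assay, taking the methyl off the oxygen on the aromatic ring moves the number sharply upward, with an at least 8.3-fold higher number from compound 2 to compound 3 (0.91 log units; beyond the scatter); until now, this place had shown only a drop, when methoxy replaced sulfamoyl. For the compounds shown here, the hydroxy compound also ends up ahead of the sulfamoyl compound, with a 2.8-fold higher number from compound 1 to compound 3 (0.44 log units; beyond the scatter), so sulfamoyl is not the only group here that gives a high number. The first of these steps can be read only as a minimum, because compound 2 stands at a limit of the assay: the limit of < 10000 ug/mL in this assay, at which 1 of the 3 values shown sits.

Three compounds cannot show whether the hydrogen on that oxygen is itself what matters, or how far the trend extends. Going by these compounds, how an amine or a carboxylic acid at this aromatic carbon, or a longer chain on the oxygen, would read in this assay stays open.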